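Lengthening a Sulfonamide Chain Where Nothing Yet Inhibits

The compounds below may be only part of what the source reports. "The series", "measured", "known", "first", "only" and "open" are said of these compounds alone.

Measured so far in a functional assay on MCF7 cells (Homo sapiens) for cytotoxicity, read by MTT assay, with a stated time of 72 h; a higher number here means a weaker inhibitor, a lower number a stronger inhibitor:
Compound 1, `O=C(NCc1ccc(F)cc1)c1nc(Br)c2cccnc2c1NCc1ccccc1`: "not determined" (no result reported)
Compound 2, `CS(=O)(=O)NCCCN(c1nc(C(=O)NCc2ccc(F)cc2)c(O)c2ncccc12)S(C)(=O)=O`: > 20000 nM
Compound 3, `NCCCNc1c(C(=O)NCc2ccc(F)cc2)ncc2cccnc12`: > 10000 nM

Compound 2 gives only a limit of the assay, > 20000 nM, and no single number is known for it. Compound 3 likewise reaches only a limit, > 10000 nM. Compound 1 has no result at all. Among the measured compounds shown here, compound 2 therefore stands at the limit of > 20000 nM in this assay, at which 1 of the 3 values shown sits, with nothing firmer to compare against, and no step between measured compounds can be sized. Compound 4, `CS(=O)(=O)NCCCCCCN(c1nc(C(=O)NCc2ccc(F)cc2)c(O)c2ncccc12)S(C)(=O)=O`, differs from compound 2 in one place: 3-(methanesulfonamido)propyl in place of methanesulfonamido on a saturated chain carbon, three bonds along the chain from a sulfonamide nitrogen. With compound 2 and compound 3 both at limits, the expected step is none beyond the scatter, and compound 4 is expected to remain at or beyond a limit as well. The estimate for compound 4 is 30000 nM, within 10000 nM to 100000 nM. The step this estimate implies, a step that the limit leaves unreadable from compound 2 to compound 4, is expected to be small.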

Compound 4, half-maximal inhibitory concentration: 7000 nM
Compound 4: middle estimate off by 4.3-fold (0.63 log units), on the high side; the whole stated range lies above it.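

In this assay, putting 3-(methanesulfonamido)propyl in place of methanesulfonamido on a saturated chain carbon gives an at least 2.8-fold lower number from compound 2 to compound 4 (0.45 log units; beyond the scatter), so this position does respond to the change. Among the compounds shown here, compound 4 is the only compound here with a single number, 7000 nM, rather than a limit. The step is only a minimum, since compound 2 has no single number: the limit of > 20000 nM in this assay, at which 1 of the 4 values shown sits.

As far as these compounds go, whether a longer chain would lower the number further stays open. So does whether a carboxylic acid in place of the methanesulfonamido would keep the gain.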